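The source may report more compounds than this note shows. Statements on the series, on what has been measured and on what is new or still open speak of the compounds shown alone.

In an ADME assay on MT4 cells (Homo sapiens) for cytotoxicity, read by MTT assay, with a stated time of 96 h (a higher number here means that more compound is tolerated, a lower number that less compound is tolerated), compound 1 `Cc1cccc(C2CC(c3ccc(Oc4ccccc4)cc3)=NN2c2ccc(S(N)(=O)=O)cc2)c1` gives 35000 nM and compound 2 `NS(=O)(=O)c1ccc(N2N=C(c3ccc(Oc4ccccc4)cc3)CC2c2cccc(F)c2)cc1` gives 25000 nM. Compound 3 `NS(=O)(=O)c1ccc(N2N=C(c3ccc(Oc4ccccc4)cc3)CC2c2cccc(Cl)c2)cc1` gives 8000 nM, the lowest of these three numbers. Compound 4 `NS(=O)(=O)c1ccc(N2N=C(c3ccc(Oc4ccccc4)cc3)CC2c2ccc(F)cc2)cc1` has 4-fluorophenyl in place of 3-chlorophenyl on a saturated ring carbon. The closest guide is a 3.1-fold lower number from compound 2 to compound 3 (0.49 log units; beyond the scatter), a modest step beyond the scatter, where chloro replaces fluoro. Swapping methyl for chloro gives a similar a 4.4-fold lower number from compound 1 to compound 3 (0.64 log units; beyond the scatter), while swapping methyl for fluoro gives a 1.4-fold lower number from compound 1 to compound 2 (0.15 log units; within the scatter), within the scatter. Going by the values given here, no measured compound carries 4-fluorophenyl, so that part remains untested. A modest rise in this assay is therefore expected, an estimated 2.5-fold higher number from compound 3 to compound 4 (0.40 log units; beyond the scatter). The expected value for compound 4 is 20000 nM, with an estimated range of 8000 nM to 50000 nM.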

Compound 4, half-maximal cytotoxic concentration: 33000 nM
Estimate against measurement, compound 4: 1.7-fold (0.22 log units) below, and the stated range covers the measured number.
By their numbers in this assay, from the lowest: compound 3; then compounds 2, 4 and 1 (each within the scatter of the next).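

In this assay there is a 4.1-fold higher number from compound 3 to compound 4 (0.62 log units; beyond the scatter) when 4-fluorophenyl replaces 3-chlorophenyl on the saturated ring carbon. Moving the fluorine gives only a 1.3-fold higher number from compound 2 to compound 4 (0.12 log units; within the scatter) and replacing 3-methylphenyl gives a 1.1-fold lower number from compound 1 to compound 4 (0.03 log units; within the scatter) so both changes stay within the scatter. Compound 3 alone stands apart from the other three compounds, and no measurement here explains why. Still open, from the compounds shown here alone, is whether 4-chlorophenyl would give a low number like 3-chlorophenyl, and how an amine or a carboxylic acid on this phenyl ring would behave.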